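This account rests on a few compounds, and the source may have more. Where it says the series, first, only, none or still open, it means among the compounds named here.

Working notes on the series. In an assay on isolated protein with Bile acid receptor (Homo sapiens) as the target (a lower number here means that less compound is needed, a higher number that more compound is needed for the effect), compound 1 `COC(=O)/C=C/c1cccc(N(Cc2ccc(/C=C/c3cccc(F)c3)cc2)C(=O)C2CCCCC2)c1` gives 86 nM, compound 2 `COC(=O)/C=C/c1cccc(N(Cc2ccc(-c3cccc(C(C)=O)c3)cc2)C(=O)C2CCCCC2)c1` gives 227 nM, and compound 3 `COC(=O)/C=C/c1cccc(N(Cc2ccc(-c3ccc(SC)cc3)cc2)C(=O)C2CCCCC2)c1` gives 69 nM, the lowest number of the three, though compound 1 sits within the scatter of it. The measured steps are a 2.6-fold higher number from compound 1 to compound 2 (0.42 log units; beyond the scatter), a 3.3-fold lower number from compound 2 to compound 3 (0.52 log units; beyond the scatter) and a 1.2-fold lower number from compound 1 to compound 3 (0.10 log units; within the scatter). Compound 4 `COC(=O)/C=C/c1cccc(N(Cc2ccc(/C=C/c3cccc(Cl)c3)cc2)C(=O)C2CCCCC2)c1` differs from compound 3 by 2-(3-chlorophenyl)ethenyl in place of 4-(methylsulfanyl)phenyl on an aromatic carbon. Within the data shown here, the step that bears on this is a 1.2-fold lower number from compound 1 to compound 3 (0.10 log units; within the scatter), the same exchange run the other way and within the scatter; for 3-chlorophenyl against 3-fluorophenyl on the ethenyl group no measured step exists. The expected step in this assay for compound 4 is therefore a 1.1-fold higher number from compound 3 to compound 4 (0.04 log units; within the scatter), nothing beyond the scatter. Compound 4 is estimated at 75 nM, within 35 nM to 160 nM.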

Compound 4, half-maximal effective concentration: 165 nM
Compound 4: middle estimate off by 2.2-fold (0.34 log units), on the low side; the whole stated range lies below it.
By their numbers in this assay, from the lowest: compounds 3, 1, 4 and 2 (each within the scatter of the next, the first and the last beyond it).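

The exchange at this position is not neutral in every case: with 2-(3-chlorophenyl)ethenyl in place of 4-(methylsulfanyl)phenyl there is a 2.4-fold higher number from compound 3 to compound 4 (0.38 log units; beyond the scatter), whereas the fluoro counterpart, compound 1, stayed within the scatter of compound 3. Chloro in place of fluoro is itself no clear change, with a 1.9-fold higher number from compound 1 to compound 4 (0.28 log units; within the scatter), and the exchange for 3-acetylphenyl is also within the scatter, with a 1.4-fold lower number from compound 2 to compound 4 (0.14 log units; within the scatter). No available evidence bears on these steps. Still open, as far as these compounds go, is how a bromo or methoxy group on the ethenyl-linked phenyl ring would read, and whether a carboxylic acid in place of the methyl ester would hold these values.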